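Trifluoromethyl in place of methyl at a second position

The compounds below may be only part of what the source reports. "The series", "measured", "known", "first", "only" and "open" are said of these compounds alone.

Measured in a functional assay on CEM-SS cells (Homo sapiens) for cytotoxicity; on this read-out lower numbers stand for stronger inhibition and higher numbers for weaker inhibition:
compound 1 `Cc1ccc(Cn2c(Br)nc3cc(Cl)c(Cl)cc32)cc1` gives > 100000 nM, a limit of the assay.
compound 2 `FC(F)(F)c1ccc(Cn2c(Br)nc3cc(Cl)c(Cl)cc32)cc1` gives > 100000 nM, a limit of the assay.
compound 3 `Cc1cccc(Cn2c(Br)nc3cc(Cl)c(Cl)cc32)c1` gives > 100000 nM, a limit of the assay.

Compound 1 and compound 2 share a core and differ by trifluoromethyl in place of methyl on an aromatic carbon. The step that the two limits leave unreadable from compound 1 to compound 2 cannot be sized, since (the limit of > 100000 nM in this assay, at which 3 of the 3 values shown sit). Compound 3 is built from the same atoms as compound 1, joined differently; the difference between the two cores is not broken down here.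

Compound 4 `FC(F)(F)c1cccc(Cn2c(Br)nc3cc(Cl)c(Cl)cc32)c1` has not yet been measured in this assay. It differs from compound 3 by trifluoromethyl in place of methyl on an aromatic carbon. This is the same kind of change as that from compound 1 to compound 2, but not the same: in compound 2 the entering group sits para to a large group, in compound 4 meta to a large group.

Compound 4 is expected to show a step that the limit leaves unreadable from compound 3 to compound 4, an expectation resting on compound 3, whose value > 100000 nM is a limit, and on (the limit of > 100000 nM in this assay, at which 3 of the 3 values shown sit). Compound 4 is therefore estimated at 150000 nM, most likely reported again only as a limit.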

Compound 4, half-maximal inhibitory concentration: > 100000 nM
Compound 4: only a limit was reported; the forecaster's own chance of this, stated with the estimate: 85%; the middle value does not contradict the limit.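

In this assay compound 4 gives > 100000 nM (a limit of the assay). Compound 3 also stands only at a limit, so no step from compound 3 to compound 4 can be read: the limit of > 100000 nM in this assay, at which 4 of the 4 values shown sit.

The compounds shown leave open whether trifluoromethyl in place of methyl changes this read-out in either position.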